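Swapping a methyl for propylcarbamoyl on a chloro-bearing core

A few compounds are considered here, and "the series" means these few. Any claim that something is new, unique, unknown or untested is made for them only; others in the source may bear on it.

Of the compounds shown here, three have been measured in a functional assay on NCI-H1975 cells (Homo sapiens) for antiproliferative activity, with a stated time of 72 h; on this read-out higher numbers stand for weaker inhibition of growth and lower numbers for stronger inhibition of growth. Compound 1 `CCCNC(=O)c1ccc(CN(C)C(=O)c2cc(C(C)C)c(O)cc2O)cc1` gives 420 nM. Compound 2 `COc1ccc(CN(C)C(=O)c2cc(Cl)c(O)cc2O)cc1` gives 16700 nM, and compound 3 `Cc1ccc(CN(C)C(=O)c2cc(Cl)c(O)cc2O)cc1` gives 34300 nM, the highest of the three numbers. Among the compounds with values here, the single measured step, a 2.1-fold higher number from compound 2 to compound 3 (0.31 log units; beyond the scatter), concerns a different change and bears only loosely on the one at hand. Compound 4 `CCCNC(=O)c1ccc(CN(C)C(=O)c2cc(Cl)c(O)cc2O)cc1` differs from compound 3 by propylcarbamoyl in place of methyl on an aromatic carbon. Compound 1 carries the same entering group on a different core and shows a far lower number, so a large drop is expected for compound 4, though the core difference leaves the size uncertain. The expected step is a 14-fold lower number from compound 3 to compound 4 (1.14 log units; beyond the scatter). Compound 4 is estimated at 2500 nM, with a range from 600 nM to 10000 nM.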

Compound 4, concentration for 50% growth inhibition: 20800 nM
Compound 4: the middle estimate sits 8.3-fold (0.92 log units) below what was measured; measured number outside the range, above it.
By their numbers in this assay, from the lowest: compound 1; then compounds 2, 4 and 3 (each within the scatter of the next, the first and the last beyond it).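

On the chloro-bearing core, the propylcarbamoyl group at this position barely separates from the smaller groups: methyl (a 1.6-fold lower number from compound 3 to compound 4 (0.22 log units; within the scatter)) and methoxy (a 1.2-fold higher number from compound 2 to compound 4 (0.10 log units; within the scatter)) both stay within the scatter. The large gap (a 50-fold higher number from compound 1 to compound 4 (1.69 log units; beyond the scatter)) goes with chloro in place of isopropyl, the one place where the two compounds differ. No outside evidence explains this result. Going by these compounds, it remains open whether an amine, a carboxylic acid or a longer chain here would shift the number on the chloro-bearing core. On these data alone, whether methyl or methoxy would keep the number low on the core of compound 1 is also open.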